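Dichlorophenyl sulfonamide as the next step in kallikrein-7 series

A few compounds are considered here, and "the series" means these few. Any claim that something is new, unique, unknown or untested is made for them only; others in the source may bear on it.

Of the compounds shown here, two sharing one core have been measured in an assay on isolated protein for inhibition of kallikrein-7 (Homo sapiens), read by fluorescence, with stated times of 10 min and 30 min; a higher number here means a weaker inhibitor, a lower number a stronger inhibitor. Compound 1, with the structure `CC1=NC(c2cn(S(=O)(=O)c3ccccc3)c3ccc(C)cc23)CN1`, gives 17000 nM in this assay. Compound 2, with the structure `CC1=NC(c2cn(S(=O)(=O)c3ccccc3F)c3ccc(C)cc23)CN1`, gives 4100 nM in this assay. Between them lies a single change, fluoro in place of hydrogen on an aromatic carbon, and it yields a 4.1-fold lower number from compound 1 to compound 2 (0.62 log units; beyond the scatter). Compound 2 therefore stands with the lowest of the two numbers, and the nearest measured compound, compound 1, sits a clear distance above it.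

Compound 3, with the structure `CC1=NC(c2cn(S(=O)(=O)c3c(Cl)cccc3Cl)c3ccc(C)cc23)CN1`, is not yet measured in this assay. It differs from compound 2 in one place: 2,6-dichlorophenyl in place of 2-fluorophenyl on a sulfonyl sulfur. For the measured compounds named here, the only measured step that bears on this change is the one from compound 1 to compound 2, where a halogen entered the phenyl on the sulfonyl sulfur and the number fell well beyond the scatter. On that basis the step is expected to run in the same direction, with a 2.7-fold lower number from compound 2 to compound 3 (0.44 log units; beyond the scatter). Compound 3 is thus estimated at 1500 nM in this assay, within a range of 400 nM to 6000 nM.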

Compound 3, half-maximal inhibitory concentration: 14000 nM
For compound 3 the middle estimate is 9.3-fold (0.97 log units) below the measured one, outside the stated range (above it).
By their numbers in this assay, from the lowest: compound 2; then compounds 3 and 1 (each within the scatter of the next).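

In this assay, the gain seen with 2-fluorophenyl on a sulfonyl sulfur does not carry over to 2,6-dichlorophenyl: that change gives a 3.4-fold higher number from compound 2 to compound 3 (0.53 log units; beyond the scatter), so the number goes up where the earlier halogen step took it down. Measured against phenyl at the same place, 2,6-dichlorophenyl gives a 1.2-fold lower number from compound 1 to compound 3 (0.08 log units; within the scatter), which shows that a halogen on this ring does not by itself lower the number, and compound 2 stays the strongest of the three, with its steps to both of the others beyond the scatter. Nothing measured here speaks to why the two halogen-bearing groups part ways at this position.

The compounds shown leave the kind of halogen and the number of halogens tied together, as 2,6-dichlorophenyl differs from 2-fluorophenyl in both, so it stays open which of the two matters in this series. As far as these compounds go, it also stays open how a phenyl carrying a single chlorine, or one carrying a methoxy group, would compare with compound 2 at this place on the sulfonyl sulfur.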